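Aryl swap on the shared core: compound 2 to compound 4

The compounds below may be only part of what the source reports. "The series", "measured", "known", "first", "only" and "open" are said of these compounds alone.

Of the compounds shown here, three on the shared core have been measured in a functional assay on KB cells (Homo sapiens) for antiproliferative activity, read by sulforhodamine B assay, with a stated time of 3 days; a higher number here means that more compound is needed for the effect, a lower number that less compound is needed. Compound 1 `CCC1=C(O)c2c(oc(-c3ccc(C(F)(F)F)cc3)cc2=O)C(CC)(CC)C1=O` gives 35.7 uM. For compound 2 `CCOc1ccc(-c2cc(=O)c3c(o2)C(CC)(CC)C(=O)C(CC)=C3O)cc1` the assay reports only a limit, > 52.4 uM. For compound 3 `CCCOc1ccc(-c2cc(=O)c3c(o2)C(CC)(CC)C(=O)C(CC)=C3O)cc1` the result is likewise a limit, > 50.5 uM. Compound 2 therefore stands at a limit rather than a number, and the same holds for compound 3 (the limit of > 52.4 uM in this assay, at which 1 of the 3 values shown sits, (the limit of > 50.5 uM in this assay, at which 1 of the 3 values shown sits)), so the series has one readable value and two limits.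

Compound 4 `CCC1=C(O)c2c(oc(-c3ccccc3C)cc2=O)C(CC)(CC)C1=O` differs from compound 2 in one place: 2-methylphenyl in place of 4-ethoxyphenyl on an aromatic carbon. The measured steps that touch this aromatic group are an at least 1.4-fold higher number from compound 1 to compound 2 (0.16 log units; that floor lies within the scatter) and an at least 1.4-fold higher number from compound 1 to compound 3 (0.15 log units; that floor lies within the scatter); the step that the two limits leave unreadable from compound 2 to compound 3 adds nothing readable. For the measured compounds named here, no measured step introduces a 2-methylphenyl, so the size of this change cannot be scaled from the series, and only a weak effect is known for every aryl group tried. Compound 4 is expected to sit in the same high-concentration region, estimated at 40 uM (range 15 uM to 120 uM). The expected step of an at least 1.3-fold lower number from compound 2 to compound 4 (0.11 log units; that floor lies within the scatter) is one that a limit would leave unreadable.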

Compound 4, concentration for half-maximal effect: 40.9 uM
Estimate against measurement, compound 4: 1.0-fold (0.01 log units) below, and the stated range covers the measured number.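

In this assay compound 4, with 2-methylphenyl on the aromatic carbon next to the ring oxygen, gives a readable number, 40.9 uM, the second in the series besides compound 1 at 35.7 uM. The swap from 4-ethoxyphenyl, which drops the only hydrogen-bond acceptor of the aryl group, reads as an at least 1.2-fold lower number from compound 2 to compound 4 (0.10 log units; that floor lies within the scatter), so no gain can be claimed for this change, and the aryl groups shown all remain in the same high-concentration region. The step stays a floor because compound 2 stands only at a limit: the limit of > 52.4 uM in this assay, at which 1 of the 4 values shown sits.

Still open, from the compounds shown here alone, is whether any group at this aromatic carbon can bring the number down beyond the scatter, for instance an aryl group carrying an amine or a carboxylic acid. How much the methyl on the phenyl ring contributes also stays open, as unsubstituted phenyl is not among the compounds shown.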